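A few compounds are considered here, and "the series" means these few. Any claim that something is new, unique, unknown or untested is made for them only; others in the source may bear on it.

Measured in an ADME assay on a cell-free system (plasma, Homo sapiens) for metabolic stability, with Plasma (Rattus norvegicus) as the target, read by HPLC, at pH 7.4; a higher number here means that the compound lasts longer, a lower number that the compound disappears faster:
compound 1, `CC(=O)Oc1ccccc1C(=O)O[C@H]1CO[C@H]2[C@@H]1OC[C@H]2OC(=O)c1snnc1C`: 0.0065 h
compound 2, `CC(=O)Oc1ccccc1C(=O)O[C@H]1CO[C@H]2[C@@H]1OC[C@H]2OC(=O)C1CC1`: 0.015 h
compound 3, `COc1ccc(C(=O)O[C@@H]2CO[C@H]3[C@@H]2OC[C@@H]3OC(=O)c2ccccc2OC(C)=O)cc1`: 0.0183 h

Compound 2 stands second highest of the three half-lives. Its nearest neighbour is compound 3, the step of a 1.2-fold higher number from compound 2 to compound 3 (0.09 log units; within the scatter) lying within the scatter, while the step of a 2.3-fold higher number from compound 1 to compound 2 (0.36 log units; beyond the scatter) is beyond it. Compound 4, `CC(=O)Oc1ccccc1C(=O)O[C@H]1CO[C@H]2[C@@H]1OC[C@H]2OC(=O)CCO[N+](=O)[O-]`, has not yet been measured in this assay. It differs from compound 2 in one place: 2-(nitrooxy)ethyl in place of cyclopropyl on a carbonyl carbon. The measured steps that exchange the group on this carbonyl carbon are a 2.3-fold higher number from compound 1 to compound 2 (0.36 log units; beyond the scatter) and a 2.8-fold higher number from compound 1 to compound 3 (0.45 log units; beyond the scatter), both modest, and a 1.2-fold higher number from compound 2 to compound 3 (0.09 log units; within the scatter), within the scatter; all three half-lives sit in a narrow band of minutes. Among the compounds with values here, none of the measured compounds carries a group like 2-(nitrooxy)ethyl, so the step to compound 4 has no direct precedent in this set. A step of the modest size seen so far, in either direction, is plausible; nothing in the data supports a larger one. The expected step from compound 2 to compound 4 is a 1.5-fold lower number from compound 2 to compound 4 (0.18 log units; within the scatter), not beyond the scatter. For compound 4 the estimated half-life is 0.01 h, with a range from 0.004 h to 0.03 h.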

Compound 4, half-life: 0.0217 h
For compound 4 the middle estimate is 2.2-fold (0.34 log units) below the measured one; the range from low to high includes it.
By their numbers in this assay, from the lowest: compound 1; then compounds 2, 3 and 4 (each within the scatter of the next).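

In this assay, the open-chain 2-(nitrooxy)ethyl, which has no ring, leaves the half-life within the scatter of both ring-bearing neighbours on this carbonyl carbon: a 1.4-fold higher number from compound 2 to compound 4 (0.16 log units; within the scatter) and a 1.2-fold higher number from compound 3 to compound 4 (0.07 log units; within the scatter). The earlier compounds had shown this only for an exchange between two ring-bearing groups, so the position now accepts a change from cyclopropyl or 4-methoxyphenyl to a chain with hydrogen-bond acceptors without a step beyond the scatter; compounds 2, 3 and 4 cannot be told apart here, and the 4-methyl-1,2,3-thiadiazol-5-yl of compound 1 is the only group that stands apart, with a 3.3-fold higher number from compound 1 to compound 4 (0.52 log units; beyond the scatter) the widest step in the set. Nothing given here bears on why the half-life behaves this way at this position.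

From the compounds shown here alone, whether an amine, a carboxylic acid or a longer chain on this carbonyl carbon would carry the half-life beyond this narrow band remains open. The values also do not show whether the disappearance begins at this ester or elsewhere in the shared core, so the group exchanged here may not be the part that sets the half-life.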